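This account rests on a few compounds, and the source may have more. Where it says the series, first, only, none or still open, it means among the compounds named here.

Measured so far:
- compound 1, `CC(C)(C)c1ccc(C(=O)N2CCC3(CC2)C(=O)N(CC(=O)N2CCC(CCO)CC2)CN3c2ccccc2)cc1`, 2600 nM
- compound 2, `CC(C)(C)c1ccc(C(=O)N2CCC3(CC2)C(=O)N(CC(=O)NCCN)CN3c2ccccc2)cc1`, 7000 nM

Both values come from an assay on HEK293 cells for displacement of a labelled ligand from NPC1-like intracellular cholesterol transporter 1 (Homo sapiens); a lower number here means a stronger inhibitor, a higher number a weaker inhibitor. Within the data shown here, compound 2 has the higher, and so weaker, of the two numbers: the single step that relates them, a 2.7-fold higher number from compound 1 to compound 2 (0.43 log units; beyond the scatter), is a modest but real loss, and it arose when the ring-bearing group on the carbonyl carbon was exchanged for a short open chain.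

Compound 3, `CC1(C)CC(OC(=O)CN2CN(c3ccccc3)C3(CCN(C(=O)c4ccc(C(C)(C)C)cc4)CC3)C2=O)CC(C)(C)N1`, has not been measured. It differs from compound 2 in one place: (2,2,6,6-tetramethylpiperidin-4-yl)oxy in place of (2-aminoethyl)amino on a carbonyl carbon. The change therefore goes back from an open chain to a six-membered ring bearing a nitrogen, though the link to the carbonyl carbon is now through oxygen rather than nitrogen.

Among the measured compounds shown here, only the step from compound 1 to compound 2 bears on this. It showed that the ring-bearing group gave the lower number, so for compound 3 a modest gain is expected, roughly undoing that step, with the step of a 2.3-fold lower number from compound 2 to compound 3 (0.37 log units; beyond the scatter) estimated to be small. In this assay compound 3 is expected to give about 3000 nM, within a range of 1000 nM to 9000 nM.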

Compound 3, half-maximal inhibitory concentration: 1300 nM
Beside the measured number, compound 3's estimate is 2.3-fold (0.36 log units) above it; the measured number falls inside the stated range.
By their numbers in this assay, from the lowest: compounds 3 and 1 (each within the scatter of the next); then compound 2.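

The step from the open chain to a second ring-bearing group, a 5.4-fold lower number from compound 2 to compound 3 (0.73 log units; beyond the scatter) in this assay, shows that this site on the carbonyl carbon accepts the much larger (2,2,6,6-tetramethylpiperidin-4-yl)oxy group, with 11 heavy atoms in place of 4. Among these three compounds, both ring-bearing groups give lower numbers than the (2-aminoethyl)amino chain, and none goes against this. The two ring-bearing groups themselves cannot be told apart, as a 2.0-fold lower number from compound 1 to compound 3 (0.30 log units; within the scatter) shows, even though one reaches the carbonyl carbon through oxygen and the other through its ring nitrogen, and nothing available here explains any of these differences.

The ring, the overall size of the group, its methyl groups and its link to the carbonyl carbon all change together, so their separate contributions remain unresolved. A plain piperidin-4-yloxy group without the four methyl groups, and an open chain of similar length ending in an amine, would help to pull these contributions apart.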